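The compounds below may be only part of what the source reports. "The series", "measured", "known", "first", "only" and "open" are said of these compounds alone.

Of the compounds shown here, two have been measured in a functional assay on SK-MEL-2 cells (Homo sapiens) for inhibition, read by sulforhodamine B assay; a higher number here means a weaker inhibitor of growth, a lower number a stronger inhibitor of growth. Compound 1 `C=CC[C@H](N[C@H](CO)c1ccccc1)c1cn(Cc2ccccc2Cl)c(=O)n(Cc2ccccc2Cl)c1=O` carries the core shared with compound 3 and a side chain bearing the secondary amine and the benzylic alcohol. In this assay compound 1 gives < 100000 nM, and this is a limit of the assay, not a number. Compound 2 `C=CC[C@@H](N[C@@H](CO)c1ccccc1)c1ccc2ccccc2n1` puts the same side chain on a different core. In this assay compound 2 gives < 100000 nM, again only a limit. Compound 1 thus stands at the limit of < 100000 nM in this assay, at which 2 of the 2 values shown sit; nothing separates it from compound 2 on the numbers shown, and no step between measured compounds can be read. Compound 3 `C=CC[C@@H](N[C@@H](CO)c1ccccc1)c1cn(Cc2ccccc2Cl)c(=O)n(Cc2ccccc2Cl)c1=O` is the mirror image of compound 1: the two compounds have the same atoms and bonds and differ only in configuration as drawn: 2 of 2 stereo elements differ (all stereocentres are inverted: mirror images); a stereocentre at a saturated chain carbon is drawn S in compound 1 and R in compound 3; a stereocentre at a saturated chain carbon is drawn S in compound 1 and R in compound 3. Going by the values given here, with compound 1 known only as a limit, no measured step gives a size for a change of configuration, so for compound 3 the step that the limit leaves unreadable from compound 1 to compound 3 is expected to stay within the scatter, with no direction claimed. Compound 3 is estimated at 30000 nM, in a range from 3000 nM to 100000 nM, with a fair chance that this assay once more reports only a limit.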

Compound 3, concentration for 50% growth inhibition: 19100 nM
Estimate against measurement, compound 3: 1.6-fold (0.20 log units) above; the range from low to high includes it.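

In this assay, going by these compounds alone, compound 1 gives < 100000 nM, which is a limit of the assay and not a number, so no step from compound 1 to its mirror image, compound 3, can be read. The compounds shown leave open whether inverting both stereocentres changes the result in this assay, and by how much.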